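This account rests on a few compounds, and the source may have more. Where it says the series, first, only, none or still open, it means among the compounds named here.

Compounds measured so far:
- compound 1, `COc1cccc(/C=C2\CCC/C(=C\c3ccccc3Cl)C2=O)c1OC`: 11700 nM
- compound 2, `COc1cccc(/C=C2\CCC/C(=C\c3cccc(Cl)c3)C2=O)c1OC`: 10300 nM
- compound 3, `COc1cccc(/C=C2\CCC/C(=C\c3ccc(Br)cc3)C2=O)c1OC`: 13700 nM

All three share one core and differ only in the phenyl group carried on a double-bonded chain carbon bound to a double-bonded ring carbon. In a functional assay on HT-1080 cells (Homo sapiens) for cytotoxicity, read by MTT assay, with a stated time of 72 h (a higher number here means a weaker inhibitor, a lower number a stronger inhibitor), compound 1 gives 11700 nM, which places it second highest of the three numbers; its nearest neighbour is compound 2, with a 1.1-fold lower number from compound 1 to compound 2 (0.06 log units; within the scatter), and its furthest is compound 3, with a 1.2-fold higher number from compound 1 to compound 3 (0.07 log units; within the scatter). The remaining pair shows a 1.3-fold higher number from compound 2 to compound 3 (0.12 log units; within the scatter). In short, moving a chlorine from one ring position to another, or swapping it for a bromine, left the numbers indistinguishable.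

Compound 4, `COc1cccc(/C=C2\CCC/C(=C\c3ccc(O)cc3)C2=O)c1OC`, has not yet been measured in this assay. It differs from compound 1 as follows: 4-hydroxyphenyl in place of 2-chlorophenyl on a double-bonded chain carbon bound to a double-bonded ring carbon

Among the compounds with values here, none of the measured steps puts a hydroxyl on this ring; the steps that do bear on it show only that changing the halogen and its position gave no step beyond the scatter. An unmeasured hydroxyl is a larger departure, so the uncertainty is wider, but no direction is supported. Compound 4 is therefore expected to give 12000 nM in this assay, within 4000 nM to 36000 nM, corresponding to an expected 1.0-fold higher number from compound 1 to compound 4 (0.01 log units; within the scatter).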

Compound 4, half-maximal inhibitory concentration: > 20000 nM
Compound 4 ended at the assay's limit; the forecaster's own chance of this, stated with the estimate: 5%; at least 1.6-fold (0.22 log units) between middle value and limit.
By their numbers in this assay, from the lowest: compounds 2, 1 and 3 (each within the scatter of the next). At a limit, above all of these: compound 4.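

In this assay compound 4 gives > 20000 nM, which is a limit of the assay and not a number: the limit of > 20000 nM in this assay, at which 1 of the 4 values shown sits.

The comparisons with the other compounds can therefore give only minimum sizes: an at least 1.7-fold higher number from compound 1 to compound 4 (0.23 log units; that floor lies within the scatter), an at least 1.4-fold higher number from compound 3 to compound 4 (0.16 log units; that floor lies within the scatter) and an at least 1.9-fold higher number from compound 2 to compound 4 (0.28 log units; that floor lies within the scatter). Within the data shown here, the earlier chlorine and bromine changes all stayed within the scatter, so 4-hydroxyphenyl is the first group here to reach the limit, which suggests that this place on a double-bonded chain carbon bound to a double-bonded ring carbon may not accept every group equally, although each minimum is still too small to establish a real loss of activity.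

Going by these compounds, how far the true value of compound 4 lies past the limit remains open, so the size of the change, which could be small or large, is unknown. On these data alone, it is also open whether the hydroxy group is a special case, since a phenyl group carrying an amine or a carboxylic acid in the same place might also reach the limit or might give a measurable number.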